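The source may hold more compounds than are shown below. What is called first, only, known or untested is meant among the compounds shown, and "the series" means these compounds.

In a functional assay on DU-145 cells (Homo sapiens) for cytotoxicity, read by trypan blue exclusion, with a stated time of 96 h (on this read-out higher numbers stand for weaker inhibition and lower numbers for stronger inhibition), two compounds have been measured so far. Compound 1 `COC(=O)C(C)(C)Nc1cc(NS(=O)(=O)/C=C/c2c(OC)cc(OC)cc2OC)ccc1OC` gives 200 nM, and compound 2 `COc1cc(OC)c(/C=C/S(=O)(=O)Nc2ccc(OC)c(NC(C)C(=O)O)c2)c(OC)c1` gives 40 nM, the lower of the two numbers and so the stronger inhibition. The next compound to be measured is compound 3 `COc1cc(OC)c(/C=C/S(=O)(=O)Nc2ccc(OC)c(NC(C)(C)C(=O)O)c2)c(OC)c1`, which differs from compound 2 by one small change: methyl in place of hydrogen on a saturated chain carbon bound to a carbonyl carbon, a nitrogen on an aromatic ring and a saturated chain carbon. A methyl replaces a hydrogen on a saturated chain carbon bound to a carbonyl carbon, a nitrogen on an aromatic ring and a saturated chain carbon, turning 1-carboxyethyl into 1-carboxy-1-methylethyl.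

Among the measured compounds shown here, only one measured step bears on this: a 5.0-fold lower number from compound 1 to compound 2 (0.70 log units; beyond the scatter). That modest step combines two changes, as 1-(methoxycarbonyl)-1-methylethyl became 1-carboxyethyl, so the data cannot isolate the share of the methyl. Compound 3 shares its carboxy group with compound 2 and its extra methyl with compound 1, so only part of a 5.0-fold lower number from compound 1 to compound 2 (0.70 log units; beyond the scatter) is expected to return. The expected move is small and toward a higher number: a 1.8-fold higher number from compound 2 to compound 3 (0.24 log units; within the scatter). For compound 3, the estimated value is 70 nM, with an expected range from 25 nM to 220 nM.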

Compound 3, half-maximal inhibitory concentration: 70 nM
For compound 3 middle estimate and measured number coincide at the digits printed, within the range that was stated.
By their numbers in this assay, from the lowest: compounds 2 and 3 (each within the scatter of the next); then compound 1.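

Adding a methyl to the saturated chain carbon, which turns 1-carboxyethyl into 1-carboxy-1-methylethyl, gives a 1.8-fold higher number from compound 2 to compound 3 (0.24 log units; within the scatter) in this assay and so leaves the number within the scatter: at this position, the methyl and the hydrogen cannot be told apart. The other new pair keeps that extra methyl and changes only the methoxycarbonyl group to a carboxy group, and this gives a 2.9-fold lower number from compound 1 to compound 3 (0.46 log units; beyond the scatter) with a size beyond the scatter. The earlier step, a 5.0-fold lower number from compound 1 to compound 2 (0.70 log units; beyond the scatter), combined both changes, and these two comparisons now pull them apart: the swap of the methoxycarbonyl group for the carboxy group is the one that clears the scatter, while the methyl alone does not.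

No measurement shown here explains why these numbers fall as they do. Going by these compounds, it remains open whether this carbon would tolerate something larger than methyl, such as an ethyl group or a cyclopropane ring, and whether an amide or a hydroxymethyl group in place of the carboxy group would keep the number as low as the carboxylic acids do.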